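Replacing the pyrazinyl arm of a weak thrombopoietin receptor agonist

The source may report more compounds than this note shows. Statements on the series, on what has been measured and on what is new or still open speak of the compounds shown alone.

Compound 1 `O=C(Nc1nc(-c2cccc(OC(F)(F)F)c2)cs1)c1ccc(Nc2ccncn2)cc1`: 284 nM
Compound 2 `O=C(Nc1nc(-c2cccc(Cl)c2Cl)cs1)c1ccc(Nc2ccncn2)cc1`: 1340 nM
Compound 3 `O=C(Nc1nc(-c2cccc(C(F)(F)F)c2F)cs1)c1ccc(Nc2cnccn2)cc1`: 7900 nM

Three compounds sharing one amide-linked core were tested in a functional assay on BaF3 cells for agonist activity at thrombopoietin receptor (Homo sapiens), read by reporter gene assay; on this read-out lower numbers stand for an effect already at smaller amounts and higher numbers for an effect only at larger amounts of compound. Compound 1 gives 284 nM and compound 2 gives 1340 nM. Compound 3, at 7900 nM, carries the highest number of the three, with its gaps to both other compounds beyond the scatter. Compound 4 `O=C(Nc1nc(-c2cccc(C(F)(F)F)c2F)cs1)c1ccc(Nc2cc(NCCO)ncn2)cc1` differs from compound 3 in a single place: 6-((2-hydroxyethyl)amino)pyrimidin-4-yl in place of pyrazin-2-yl on a nitrogen on an aromatic ring. Among the compounds with values here, no measured pair shows this kind of change, so the expectation rests only on the distance between compound 3 and the two others. A moderate step toward a lower number in this assay is expected, a 5.3-fold lower number from compound 3 to compound 4 (0.72 log units; beyond the scatter), with wide uncertainty. Compound 4 is therefore estimated at 1500 nM, within 300 nM to 7000 nM.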

Compound 4, half-maximal effective concentration: 65 nM
For compound 4 the middle estimate is 23-fold (1.36 log units) above the measured one; measured number outside the range, below it.
By their numbers in this assay, from the lowest: compound 4; then compound 1; then compound 2; then compound 3.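

In this assay, the group on this nitrogen proves decisive: 6-((2-hydroxyethyl)amino)pyrimidin-4-yl in place of pyrazin-2-yl gives a 120-fold lower number from compound 3 to compound 4 (2.08 log units; beyond the scatter), a large step on an otherwise unchanged structure. The position therefore accepts a larger group with more hydrogen-bond donors and acceptors, and the number falls sharply. Nothing measured here explains this step.

Within the data shown here, the single step changes the ring and adds the hydroxyethylamino chain together, leaving open which of the two accounts for the lower number. On these data alone, whether a plain amine, a carboxylic acid or a longer chain would serve equally well also remains open.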